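The source may hold more compounds than are shown below. What is called first, only, known or untested is meant among the compounds shown, and "the series" means these compounds.

In a functional assay on THP-1 cells (Homo sapiens) for cytotoxicity, read by MTT assay, with a stated time of 72 h (a lower number here means a stronger inhibitor, a higher number a weaker inhibitor), three compounds sharing one core have been measured. Compound 1 `C=C1C2=C(C(=O)N1OC)[C@H](OC(=O)CSc1nc3ccccc3o1)[C@@](C)(O)[C@H](CCCCC)O2` gives 2300 nM, compound 2 `C=C1C2=C(C(=O)N1OC)[C@H](OC(=O)CCCCCl)[C@@](C)(O)[C@H](CCCCC)O2` gives 4600 nM, and compound 3 `C=C1C2=C(C(=O)N1OC)[C@H](OC(=O)CSc1nc3ccccc3[nH]1)[C@@](C)(O)[C@H](CCCCC)O2` gives 5300 nM. The place of compound 2 among these numbers is not sharply fixed, since neither of its gaps exceeds the scatter: the data show a 2.0-fold higher number from compound 1 to compound 2 (0.30 log units; within the scatter) and a 1.2-fold higher number from compound 2 to compound 3 (0.06 log units; within the scatter). Only a 2.3-fold higher number from compound 1 to compound 3 (0.36 log units; beyond the scatter) goes beyond it, and that modest step is a change on a sulfur.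

Compound 4 `C=C1C2=C(C(=O)N1OC)[C@H](OC(=O)CCl)[C@@](C)(O)[C@H](CCCCC)O2` differs from compound 2 by chloro in place of 3-chloropropyl on a saturated chain carbon bound to a carbonyl carbon. The same difference reads 4-chlorobutyl to chloromethyl. The two steps that replace a group at this place were both small, so large swaps there have so far moved the number little in this assay. Within the data shown here, still, no measured step shortens a chlorinated chain. No step beyond the scatter is therefore expected. The expected step is a 1.3-fold lower number from compound 2 to compound 4 (0.12 log units; within the scatter). Compound 4 is estimated at 3500 nM, with an expected range from 1300 nM to 9000 nM.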

Compound 4, half-maximal inhibitory concentration: 11000 nM
Estimate against measurement, compound 4: 3.1-fold (0.50 log units) below, and the stated range ends below it.
By their numbers in this assay, from the lowest: compounds 1, 2 and 3 (each within the scatter of the next, the first and the last beyond it); then compound 4.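

In this assay, compound 4 carries chloro at the place on a saturated chain carbon bound to a carbonyl carbon. All three steps to compound 4 lie beyond the scatter, with a 2.4-fold higher number from compound 2 to compound 4 (0.38 log units; beyond the scatter), a 2.1-fold higher number from compound 3 to compound 4 (0.32 log units; beyond the scatter) and a 4.8-fold higher number from compound 1 to compound 4 (0.68 log units; beyond the scatter). Swaps among 4-chlorobutyl and the larger (1H-benzimidazol-2-yl)sulfanyl group had stayed within the scatter, whereas compound 4 now stands as the weakest of the four, so what enters at this place does matter at the small end. Nothing shown here speaks to the cause of this rise.

The compounds shown leave open how the number runs along chlorinated chains between chloromethyl and 4-chlorobutyl, such as a 2-chloroethyl group. They also leave open whether the chlorine itself counts, which a plain butyl chain or an amine at this place would address.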